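This account rests on a few compounds, and the source may have more. Where it says the series, first, only, none or still open, it means among the compounds named here.

Compound 1 `Clc1ccc2c(O/N=C(/C=C/c3ccc(OCc4ccccc4Cl)cc3)\C=C\c3ccccn3)ncnc2c1` is measured in a functional assay on SMMC-7721 cells (Homo sapiens) for inhibition, read by MTT assay, with a stated time of 72 h, tested at 10 uM (a higher number here means a stronger effect of the compound at the concentration tested, a lower number a weaker effect), where compound 1 gives 84.7%. Among the three compounds measured, compound 1 stands second highest. Compound 2 `Clc1ccc(COc2ccc(/C=C/C(/C=C/c3ccccn3)=N/Oc3ncnc4cc(Cl)ccc34)cc2)cc1` gives 88.1%, and the step of a number 3.4 percentage points higher from compound 1 to compound 2 (within the scatter) lies within the scatter. Compound 3 `Clc1ccc(COc2ccc(/C=C/C(/C=C/c3ccccn3)=N/Oc3ncnc4cc(Cl)ccc34)cc2)c(Cl)c1` gives 23.6%, and the step of a number 61.1 percentage points lower from compound 1 to compound 3 (beyond the scatter) is large, as is a number 64.5 percentage points lower from compound 2 to compound 3 (beyond the scatter). Compound 4 `Cc1cccc2ncnc(O/N=C(/C=C/c3ccc(OCc4ccccc4Cl)cc3)\C=C\c3ccccn3)c12` differs from compound 1 in that (5-methylquinazolin-4-yl in place of 7-chloroquinazolin-4-yl on an oxygen). None of the measured steps touches the oxygen-bound ring system: the steps shown concern the chlorophenyl part only, so they give no direct guidance on this change. Among the measured compounds shown here, with no step to rest on, compound 4 is expected to stay near compound 1, with a step of a number 14.7 percentage points lower from compound 1 to compound 4 (beyond the scatter) that is estimated at about none beyond the scatter, and a wide range around it. Compound 4 is therefore estimated at 70%, between 30% and 95%.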

Compound 4, a percentage reported as inhibition, at one concentration (the size of the read-out at that concentration, not a potency): 84.7%
The estimate for compound 4 lay 14.7 percentage points below the measured number; low and high end bracket the measured number.
By their numbers in this assay, from the lowest: compound 3; then compounds 1, 4 and 2 (each within the scatter of the next).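

Among the compounds shown here, the ring on the oxygen, untouched by the earlier steps, accepts this exchange: 5-methylquinazolin-4-yl in place of 7-chloroquinazolin-4-yl gives no change at the digits printed from compound 1 to compound 4 (within the scatter) in this assay. Chlorine and its place change together here, so the two changes cannot be told apart. Nothing at hand explains the outcome.

As far as these compounds go, whether a larger or differently natured group on this ring, such as an amine, a methoxy or a carboxylic acid, would keep the read-out remains open. So does whether the loss seen with the second chlorine in compound 3 would recur with 5-methylquinazolin-4-yl.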